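A few compounds are considered here, and "the series" means these few. Any claim that something is new, unique, unknown or untested is made for them only; others in the source may bear on it.

Measured in a functional assay on HT-29 cells (Homo sapiens) for inhibition, read by luminescence and CellTiter-Glo, with a stated time of 24 h (a higher number here means that more compound is needed for the effect, a lower number that less compound is needed), so far:
- compound 1 (`CN1C(=S)[C@@H](NC(=O)c2nc(Cc3ccccc3)n(C3CCC3)n2)COc2ccccc21`) gives 181 nM
- compound 2 (`CN1C(=S)[C@@H](NC(=O)c2nc(Cc3ccccc3)n(CC3COC3)n2)COc2ccccc21`) gives 2830 nM
- compound 3 (`CN1C(=S)[C@@H](NC(=O)c2nc(Cc3ccccc3)n(C3CCN(C(=O)OC(C)(C)C)C3)n2)COc2ccccc21`) gives > 10000 nM as a limit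

Compound 3 stands at the limit of > 10000 nM in this assay, at which 1 of the 3 values shown sits, and so has a limit rather than a number. Going to compound 4 (`Cc1cnc(-n2nc(C(=O)N[C@H]3COc4ccccc4N(C)C3=S)nc2Cc2ccccc2)nc1`) brings a group of 7 heavy atoms (5 carbon, 2 nitrogen; one six-membered aromatic ring with 2 hetero atoms) in place of a group of 12 heavy atoms (9 carbon, 1 nitrogen, 2 oxygen; one five-membered non-aromatic ring with 1 hetero atom), on an aromatic nitrogen and the entering group is 5-methylpyrimidin-2-yl. Three measured steps changed this same place: a 16-fold higher number from compound 1 to compound 2 (1.19 log units; beyond the scatter) then an at least 55-fold higher number from compound 1 to compound 3 (1.74 log units; beyond the scatter) and also an at least 3.5-fold higher number from compound 2 to compound 3 (0.54 log units; beyond the scatter) as the last. Among these three compounds, the number rose as the group grew. Going by the values given here, the new group is smaller than that of compound 3 but larger than that of compound 2, and it is aromatic, which none of the measured groups is. A clear fall in the number is therefore expected in this assay but its size is uncertain, with an at least 6.6-fold lower number from compound 3 to compound 4 (0.82 log units; beyond the scatter) as the estimated step here. For compound 4 the estimated value is 1500 nM with an expected range from 200 nM to 9000 nM in this measurement.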

Compound 4, half-maximal effective concentration: 1950 nM
Compound 4: middle estimate off by 1.3-fold (0.11 log units), on the low side; measured number inside the range.
By their numbers in this assay, from the lowest: compound 1; then compounds 4 and 2 (each within the scatter of the next). At a limit, above all of these: compound 3.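

Going by these compounds alone, the first aromatic group at this ring nitrogen, 5-methylpyrimidin-2-yl, does not reach the level of cyclobutyl (an 11-fold higher number from compound 1 to compound 4 (1.03 log units; beyond the scatter)). Compared with (oxetan-3-yl)methyl it stays within the scatter (a 1.5-fold lower number from compound 2 to compound 4 (0.16 log units; within the scatter)), so these two groups cannot be told apart here, even though the order of the earlier compounds followed group size. The fall from the group of compound 3 (an at least 5.1-fold lower number from compound 3 to compound 4 (0.70 log units; beyond the scatter)) is only a minimum, as compound 3 has a limit and not a number: the limit of > 10000 nM in this assay, at which 1 of the 4 values shown sits.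

As far as these compounds go, whether phenyl or unsubstituted pyrimidin-2-yl would come closer to compound 1 stays open. So does whether cyclopentyl would match cyclobutyl.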